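A few compounds are considered here, and "the series" means these few. Any claim that something is new, unique, unknown or untested is made for them only; others in the source may bear on it.

In an ADME assay on RAW264.7 cells (Mus musculus) for cytotoxicity, read by MTT assay, with a stated time of 24 h (a lower number here means that less compound is tolerated, a higher number that more compound is tolerated), compound 1 `CC/C=C\CC1C(=O)C=CC1CC(=O)OC` gives 140 uM, and compound 2 `CC/C=C\C[C@H]1C(=O)C=C[C@H]1CC(=O)OCC` gives 146 uM; these two numbers lie within the usual scatter of each other. Compound 3 `CC/C=C\C[C@H]1C(=O)C=C[C@H]1CC(=O)OCCCCC` gives 37 uM in this assay. Among the three measured compounds, compound 3 has the lowest number, meaning the least compound is tolerated by the cells.

Compound 4 `CC/C=C\C[C@H]1C(=O)C=C[C@H]1CC(=O)Oc1ccc(O)cc1` is not yet measured. It differs from compound 3 in one place: 4-hydroxyphenyl in place of pentyl on an oxygen next to a carbonyl group. Going by the values given here, the only measured step at this part of the molecule is the one from compound 2 to compound 3, a 3.9-fold lower number from compound 2 to compound 3 (0.60 log units; beyond the scatter), where a longer chain on the oxygen next to the carbonyl group went with a lower number. Among the compounds with values here, no measured compound carries an aromatic ring on that oxygen, so that step is a rough guide only.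

Within the data shown here, because the one step in this region, a 3.9-fold lower number from compound 2 to compound 3 (0.60 log units; beyond the scatter), showed that this position can move the read-out beyond the scatter, a change of similar size is expected here, most likely back toward the numbers of compound 1 and compound 2. Compound 4 is therefore expected to give about 60 uM in this assay, within a range of 25 uM to 150 uM, which corresponds to an expected step of a 1.6-fold higher number from compound 3 to compound 4 (0.21 log units; within the scatter).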

Compound 4, half-maximal toxic concentration: 49 uM
Compound 4: middle estimate off by 1.2-fold (0.09 log units), on the high side; low and high end bracket the measured number.
By their numbers in this assay, from the lowest: compounds 3 and 4 (each within the scatter of the next); then compounds 1 and 2 (each within the scatter of the next).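

In this assay, 4-hydroxyphenyl in place of pentyl on an oxygen next to a carbonyl group gives a 1.3-fold higher number from compound 3 to compound 4 (0.12 log units; within the scatter), so this assay does not separate these two quite different groups. Measured against ethyl, the same 4-hydroxyphenyl group gives a 3.0-fold lower number from compound 2 to compound 4 (0.47 log units; beyond the scatter), a step beyond the scatter in the same direction as a 3.9-fold lower number from compound 2 to compound 3 (0.60 log units; beyond the scatter). A lower number at this position is therefore not tied to a saturated chain: compound 3 and compound 4 both show it, although compound 3 carries pentyl and compound 4 carries a six-membered aromatic ring of carbon only.

No measurement is available that would explain why these two groups give such similar results. As far as these compounds go, how a plain phenyl group, an amine on that ring or a chain longer than pentyl would compare on this oxygen remains open, as does whether the hydroxyl of compound 4 makes any difference to how much compound the cells tolerate.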